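The source may report more compounds than this note shows. Statements on the series, on what has been measured and on what is new or still open speak of the compounds shown alone.

Measured in a functional assay on HFF cells (Homo sapiens) for cytotoxicity; a higher number here means a weaker inhibitor, a lower number a stronger inhibitor:
compound 1 `Cc1ccc(/C=C2\SC(=S)N(NS(=O)(=O)c3ccccc3)C2=O)cc1`: > 100000 nM (a limit)
compound 2 `COc1cccc(/C=C2\SC(=S)N(NS(=O)(=O)c3ccccc3)C2=O)c1`: > 100000 nM (a limit)

Compound 2 has no numerical value, only the limit > 100000 nM. Compound 1 is also known only as a limit, > 100000 nM. Within the data shown here, the series so far therefore reads: the limit of > 100000 nM in this assay, at which 2 of the 2 values shown sit.

Compound 3 `O=C1/C(=C/c2ccccc2F)SC(=S)N1NS(=O)(=O)c1ccccc1` is not yet measured. It carries 2-fluorophenyl in place of 3-methoxyphenyl on a double-bonded chain carbon bound to a double-bonded ring carbon.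

Among the measured compounds shown here, the only measured step bearing on this change is at the same place: a step that the two limits leave unreadable from compound 1 to compound 2. It gives no size to carry over, and it shows only that both of these aryl groups leave the value at the limit. With so little to go on, no shift in either direction is expected in this assay. The expected step, a number no higher from compound 2 to compound 3 (the limit leaves the size open), is estimated to lie within the scatter, and a report as a limit is the likeliest outcome. For compound 3 the estimated value is 100000 nM, with an expected range of 50000 nM to 200000 nM.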

Compound 3, half-maximal inhibitory concentration: > 100000 nM
Compound 3: a limit, no number; the forecaster's own chance of this, stated with the estimate: 75%; the middle value sits exactly at the limit.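

In this assay compound 3 gives > 100000 nM and this is a limit, not a number. The steps linking compound 3 to compound 1 and to compound 2 therefore cannot be read. The compounds shown leave open whether any aryl group at this place gives a numerical value in this assay and how large a step between such groups would be.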